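Two weak thienopyridine amides and a methylphenyl variant

The compounds below may be only part of what the source reports. "The series", "measured", "known", "first", "only" and "open" are said of these compounds alone.

Measured compounds:
- compound 1, `NC(=O)c1c(NC(=O)c2ccccc2F)sc2c1CCN(Cc1ccc(Cl)cc1Cl)C2`: 13100 nM
- compound 2, `NC(=O)c1c(NC(=O)c2ccccc2Br)sc2c1CCN(C(=S)Nc1ccccc1Cl)C2`: 14600 nM

In a functional assay on HL-60 cells (Homo sapiens) for antiproliferative activity, with a stated time of 24 h (on this read-out lower numbers stand for stronger inhibition and higher numbers for weaker inhibition), compound 1 gives 13100 nM. In this assay compound 2 gives 14600 nM. Within the data shown here, compound 1 and compound 2 differ in more than one place, so no single step connects them; their two numbers lie within the scatter of each other, and compound 2 therefore stands alongside compound 1 rather than apart from it, with no ordering to be read between them.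

Compound 3, `Cc1ccc(C(=O)Nc2sc3c(c2C(N)=O)CCN(C(=S)Nc2ccccc2Cl)C3)cc1`, is not yet measured. It differs from compound 2 in one place: 4-methylphenyl in place of 2-bromophenyl on a carbonyl carbon. The shared core and the substituted thiourea are kept.

Among the measured compounds shown here, with no measured step of this kind available, the expectation rests on the two numbers alone, both weak. The step from compound 2 to compound 3 in this assay is expected to be a 1.0-fold higher number from compound 2 to compound 3 (0.01 log units; within the scatter), which is no step beyond the scatter. Compound 3 is therefore estimated to give 15000 nM in this assay. For compound 3 the expected range runs from 6000 nM to 40000 nM.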

Compound 3, half-maximal inhibitory concentration: 8430 nM
The estimate for compound 3 lay 1.8-fold (0.25 log units) above the measured number; the range from low to high includes it.
By their numbers in this assay, from the lowest: compounds 3, 1 and 2 (each within the scatter of the next).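

In this assay, among these compounds, the exchange of 2-bromophenyl for 4-methylphenyl on a carbonyl carbon gives a 1.7-fold lower number from compound 2 to compound 3 (0.24 log units; within the scatter), the first single-place step at this position. With the shared core and the substituted thiourea kept, this pair shows that the two aromatic groups cannot be told apart on this read-out, although one carries bromine and the other a methyl group, each at a different numbered place on the ring. Nothing available bears on the reason for this result.

The pair changes the substituent and its numbered place in a single step, so it leaves open whether either change alone would matter, or whether the two could have separate effects that this one comparison does not resolve. Also open, going by these compounds, is how the read-out would respond at this position to an unsubstituted phenyl ring, to a phenyl ring carrying an amine or a carboxylic acid, or to a saturated ring such as cyclohexyl in place of the aromatic group.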